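Cytotoxicity and a trifluorobutyl amine on a pyrimidine core

A few compounds are considered here, and "the series" means these few. Any claim that something is new, unique, unknown or untested is made for them only; others in the source may bear on it.

In an ADME assay on cells (Homo sapiens) for cytotoxicity, read by polymerase chain reaction, with a stated time of 3 days (a lower number here means that less compound is tolerated, a higher number that more compound is tolerated), compound 1, `Nc1nc(Cl)c(-c2ccco2)c(N[C@@H]2C[C@H](CO)[C@@H](O)[C@H]2O)n1`, reports only a limit of > 25000 nM. Compound 2, `Nc1nc(Cl)c(-c2cc3ccccc3s2)c(N[C@@H]2C[C@H](CO)[C@@H](O)[C@H]2O)n1`, likewise reports only a limit of > 25000 nM. The step that the two limits leave unreadable from compound 1 to compound 2 therefore cannot be read, a consequence of the limit of > 25000 nM in this assay, at which 2 of the 3 values shown sit. Among the measured compounds shown here, compound 3, `Cc1nc(NC(C)(C)C)nc(N[C@@H]2C[C@H](CO)[C@@H](O)[C@H]2O)c1-c1nc2ccccc2s1`, is the one compound with a number in this assay and gives 12000 nM. The values of compound 1 and compound 2 are limits of the assay.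

Compound 4, `Cc1nc(NCCCC(F)(F)F)nc(N[C@@H]2C[C@H](CO)[C@@H](O)[C@H]2O)c1-c1nc2ccccc2s1`, differs from compound 3 by 4,4,4-trifluorobutyl in place of tert-butyl on a nitrogen on an aromatic ring. For the measured compounds named here, no measured step touches this position: the one step recorded concerns a different part of the core and is itself unreadable. The change is thus unsupported by any comparison in this assay, and no shift beyond the usual scatter is expected. The step of no change at the digits printed from compound 3 to compound 4 (within the scatter) is therefore estimated as essentially flat. Compound 4 is expected to give about 12000 nM in this assay, within a range from 5000 nM to 25000 nM.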

Compound 4, half-maximal cytotoxic concentration: 3000 nM
Compound 4: the middle estimate sits 4.0-fold (0.60 log units) above what was measured; measured number below the stated range.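

In this assay, among the compounds shown here, the result gives the first readable step in this set, a 4.0-fold lower number from compound 3 to compound 4 (0.60 log units; beyond the scatter), and it falls on a nitrogen on an aromatic ring. It shows that the group on this nitrogen can move the read-out: less compound is tolerated with 4,4,4-trifluorobutyl than with tert-butyl, at least in this single pair. The earlier compounds could show nothing of the kind, since their only step concerns a different part of the core and cannot be read: the limit of > 25000 nM in this assay, at which 2 of the 4 values shown sit.

The pair does not separate the effect of the three fluorine atoms from that of the chain itself, and a plain butyl group on this nitrogen is not among the compounds shown. As far as these compounds go, whether a longer chain or a cyclic amine would lower the number further also stays open.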